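Iodo for trifluoromethyl: compound 2 to compound 3

The source may report more compounds than this note shows. Statements on the series, on what has been measured and on what is new or still open speak of the compounds shown alone.

In a functional assay on PC-9 cells (Homo sapiens) for antiproliferative activity, read by MTT assay, with a stated time of 48 h (a lower number here means a stronger inhibitor, a higher number a weaker inhibitor), compound 1 (`Cc1cc(F)cc(Nc2cc(NC(=O)Nc3c(Cl)cccc3Cl)ncn2)c1`) stands at 2790 nM while compound 2 (`COc1cc(NC(=O)Nc2cc(Nc3cc(C(F)(F)F)ccc3OC)ncn2)cc(OC)c1`) stands at 6220 nM as the higher of the two numbers, a gap beyond the scatter. Compound 3 (`COc1cc(NC(=O)Nc2cc(Nc3cc(I)ccc3OC)ncn2)cc(OC)c1`) carries iodo in place of trifluoromethyl on an aromatic carbon, para to a methoxy group. Among the compounds with values here, no measured pair differs in one place, so nothing direct guides this change. The estimated step is a 1.4-fold lower number from compound 2 to compound 3 (0.14 log units; within the scatter) in the direction of a lower number, and none beyond the scatter is expected. Compound 3 is expected in this assay at 4500 nM within a range from 1500 nM to 12000 nM pending measurement.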

Compound 3, half-maximal inhibitory concentration: 3540 nM
Compound 3: middle estimate off by 1.3-fold (0.10 log units), on the high side, within the range that was stated.
By their numbers in this assay, from the lowest: compounds 1, 3 and 2 (each within the scatter of the next, the first and the last beyond it).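

In this assay, iodo in place of trifluoromethyl on this aromatic carbon, para to a methoxy group, gives a 1.8-fold lower number from compound 2 to compound 3 (0.24 log units; within the scatter). This first single-place pair shows that one iodine atom can stand in for the four heavy atoms of trifluoromethyl here without a shift beyond the scatter. Nothing measured here explains the result. Going by these compounds, only these two groups are compared at this position, so an amine, a nitrile or a carboxylic acid there remains open. Within the data shown here, compound 1 differs from both in more than one place, so no step to it can be read.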